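The source may report more compounds than this note shows. Statements on the series, on what has been measured and on what is new or still open speak of the compounds shown alone.

Working notes on the series. Compound 2 `N#Cc1ccc(CSc2ncnc3c2ncn3[C@@H]2O[C@H](CO)[C@@H](O)[C@H]2O)cc1` gives 4.57 nM in an assay on isolated protein for inhibition of Equilibrative nucleoside transporter 1 (Homo sapiens) (a higher number here means a weaker inhibitor, a lower number a stronger inhibitor), the lowest of the two numbers in hand; compound 1 `OC[C@H]1O[C@@H](n2cnc3c(SCc4ccccc4Br)ncnc32)[C@H](O)[C@@H]1O` gives 151 nM. Going by the values given here, the one measured step, a 33-fold lower number from compound 1 to compound 2 (1.52 log units; beyond the scatter), was large and brought in the 4-cyanophenyl that compound 3 `CC(C)(C)c1ccc(CSc2ncnc3c2ncn3[C@@H]2O[C@H](CO)[C@@H](O)[C@H]2O)cc1` now loses: tert-butyl in place of cyano on an aromatic carbon. Among the compounds with values here, no step in the set swaps cyano for tert-butyl directly, so the expectation leans only on how much the 4-cyanophenyl gained in that one step. A moderate rise in this assay is expected, an 8.8-fold higher number from compound 2 to compound 3 (0.94 log units; beyond the scatter), and compound 3 is estimated at 40 nM, within 10 nM to 200 nM.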

Compound 3, inhibition constant: 10000 nM
The estimate for compound 3 lay 250-fold (2.40 log units) below the measured number, outside the stated range (above it).
By their numbers in this assay, from the lowest: compound 2; then compound 1; then compound 3.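

On this aromatic carbon the choice of group sets the result in this assay: the change gives a 2200-fold higher number from compound 2 to compound 3 (3.34 log units; beyond the scatter), so a group here can take the number far up as well as far down. The 4-(tert-butyl)phenyl also falls behind the 2-bromophenyl, with a 66-fold higher number from compound 1 to compound 3 (1.82 log units; beyond the scatter), which shows that a group at this place does not by itself carry the gain seen with the 4-cyanophenyl. Nothing in hand explains the size of this change.

Open, going by these compounds, is where a methyl, a methoxy or an amine on the same aromatic carbon would fall in the wide span between compound 2 and compound 3. Also open, on these data alone, is whether a carboxylic acid there would stay close to compound 2.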